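Changing the aryl amide of a dopamine receptor agonist

The compounds below may be only part of what the source reports. "The series", "measured", "known", "first", "only" and "open" are said of these compounds alone.

Going by the values given here, compound 1 `Cc1cc(NC(=O)CN2CCC(c3cccc[n+]3[O-])CC2)ccc1F` was tested in a functional assay on HEK293 cells for agonist activity at D(4) dopamine receptor (Homo sapiens), read by FLIPR (a higher number here means that more compound is needed for the effect, a lower number that less compound is needed), and compound 1 gives 18 nM, the lower of the two numbers known so far. Compound 2 `Cc1cccc(Cl)c1NC(=O)CN1CCC(c2ccccn2)CC1` gives 60 nM in this assay, a gap beyond the usual scatter. Compound 3 `O=C(CN1CCC(c2cccc[n+]2[O-])CC1)Nc1cc(Cl)cc(Cl)c1` has not been measured; it differs from compound 1 by a single change: 3,5-dichlorophenyl in place of 4-fluoro-3-methylphenyl on an amide-type nitrogen. Among the compounds with values here, no measured pair differs in only this place, so the expectation rests on compound 1 and its value 18 nM. Compound 3 is expected to give 30 nM, between 8 nM and 120 nM. This estimate means a small step of a 1.7-fold higher number from compound 1 to compound 3 (0.22 log units; within the scatter), within or close to the scatter.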

Compound 3, half-maximal effective concentration: 160 nM
For compound 3 the middle estimate is 5.3-fold (0.73 log units) below the measured one, and the stated range ends below it.
By their numbers in this assay, from the lowest: compound 1; then compound 2; then compound 3.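

This position on the amide nitrogen is sensitive to the aryl group: with the rest of compound 1 unchanged, 3,5-dichlorophenyl in place of 4-fluoro-3-methylphenyl gives an 8.9-fold higher number from compound 1 to compound 3 (0.95 log units; beyond the scatter) in this assay. Both groups have the same count of heavy atoms and one six-membered aromatic ring, so those counts alone do not settle the value here. Nothing available accounts for this rise.

Going by these compounds, the fluorine, methyl and chlorine substituents change together in this step, so the part each one plays stays open. On these data alone, how a plain phenyl ring or a methoxy-bearing phenyl ring would behave at this place also remains unknown.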